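A few compounds are considered here, and "the series" means these few. Any claim that something is new, unique, unknown or untested is made for them only; others in the source may bear on it.

Compound 1 `Fc1ccc(C2=NN(C(=S)Nc3ccccc3)C(c3ccc4c(c3)OCCO4)C2)cc1`, compound 2 `COc1ccccc1C1=NN(C(=S)Nc2ccccc2)C(c2ccc3c(c2)OCCO3)C1` and compound 3 `COc1cccc(C2=NN(C(=S)Nc3ccccc3)C(c3ccc4c(c3)OCCO4)C2)c1` share one core and differ only in the aryl group on a carbon with a double bond to nitrogen. In a functional assay on HCT-116 cells (Homo sapiens) for antiproliferative activity, read by MTT assay, with a stated time of 48 h (on this read-out lower numbers stand for stronger inhibition of growth and higher numbers for weaker inhibition of growth), compound 1 gives 61200 nM. For compound 2 the this assay reports only a limit, > 200000 nM. For compound 3 the this assay likewise reports only a limit, > 200000 nM, and compound 3 therefore stands at the weak end of what has been measured. The steps of an at least 3.2-fold higher number from compound 1 to compound 2 (0.51 log units; beyond the scatter) and an at least 3.2-fold higher number from compound 1 to compound 3 (0.51 log units; beyond the scatter) both lie beyond the scatter, whereas the step that the two limits leave unreadable from compound 2 to compound 3 cannot be read; two of the three values sit at the limit of > 200000 nM in this assay, at which 2 of the 3 values shown sit. Compound 4 `S=C(Nc1ccccc1)N1N=C(c2cccs2)CC1c1ccc2c(c1)OCCO2` differs from compound 3 by thiophen-2-yl in place of 3-methoxyphenyl on a carbon with a double bond to nitrogen. Among the measured compounds shown here, none of the measured steps exchanges an aryl group for thiophen-2-yl, and only compound 1 gives a number at all. Compound 4 is expected in this assay near 120000 nM, between 30000 nM and 300000 nM. The step of an at least 1.6-fold lower number from compound 3 to compound 4 (0.22 log units; that floor lies within the scatter) is thus an estimate of uncertain size.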

Compound 4, concentration for 50% growth inhibition: 8190 nM
Compound 4: the middle estimate sits 15-fold (1.17 log units) above what was measured; measured number outside the range, below it.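

In this assay, among the compounds shown here, the place on the carbon with a double bond to nitrogen now shows a gain as well as a loss: the earlier steps led only to higher numbers, whereas thiophen-2-yl brings a 7.5-fold lower number from compound 1 to compound 4 (0.87 log units; beyond the scatter), the one step here read between two actual numbers. Against the methoxyphenyl compounds the same exchange gives an at least 24-fold lower number from compound 3 to compound 4 (1.38 log units; beyond the scatter) and an at least 24-fold lower number from compound 2 to compound 4 (1.38 log units; beyond the scatter), so compound 4 is the most potent of the four, with all its steps beyond the scatter. Those last two steps are only floors, each starting from a limit of the assay: the limit of > 200000 nM in this assay, at which 2 of the 4 values shown sit.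

The compounds shown do not separate the part played by the sulfur atom from that of the five-membered ring. As far as these compounds go, how furan-2-yl or an unsubstituted phenyl group would read at this place stays open.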